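A few compounds are considered here, and "the series" means these few. Any claim that something is new, unique, unknown or untested is made for them only; others in the source may bear on it.

Two compounds share one core and differ only in the group on a carbonyl carbon. Compound 1 `CCCC(=O)N1CCC(NS(=O)(=O)c2ccc(NC(=O)c3nccn3C)c3ccccc23)CC1` carries a 1-methyl-1H-imidazol-2-yl there, and in an in vitro functional assay on CHO/Galpha16 cells for antagonist activity at C-C chemokine receptor type 8 (Homo sapiens), read by FLIPR (a higher number here means a weaker inhibitor, a lower number a stronger inhibitor), compound 1 gives 20.4 nM. Compound 2 `CCCC(=O)N1CCC(NS(=O)(=O)c2ccc(NC(=O)c3cc(C)nc(Cl)c3)c3ccccc23)CC1` carries a 2-chloro-6-methylpyridin-4-yl instead, and in this assay compound 2 gives 43.9 nM. That swap gave a 2.2-fold higher number from compound 1 to compound 2 (0.33 log units; beyond the scatter), so compound 2 stands with the higher of the two numbers, a modest distance above compound 1.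

Compound 3 `CCCC(=O)N1CCC(NS(=O)(=O)c2ccc(NC(=O)C3CCCC3)c3ccccc23)CC1` takes the change one stage further: cyclopentyl in place of 2-chloro-6-methylpyridin-4-yl on a carbonyl carbon. Among the measured compounds shown here, the only measured step, the one from compound 1 to compound 2, exchanged one aromatic ring for another; the step to compound 3 removes the aromatic ring altogether, so that step is only a loose guide. With a modest change of that size as the single reference, compound 3 is expected to shift by a 1.8-fold higher number from compound 2 to compound 3 (0.26 log units; within the scatter) in this assay, giving an estimated 80 nM, within a range of 25 nM to 300 nM.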

Compound 3, half-maximal inhibitory concentration: 365 nM
Compound 3: the middle estimate sits 4.6-fold (0.66 log units) below what was measured; the measured number lies above the stated range.
By their numbers in this assay, from the lowest: compound 1; then compound 2; then compound 3.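

In this assay, cyclopentyl on the carbonyl carbon gives an 8.3-fold higher number from compound 2 to compound 3 (0.92 log units; beyond the scatter), and measured against the 1-methyl-1H-imidazol-2-yl group it gives an 18-fold higher number from compound 1 to compound 3 (1.25 log units; beyond the scatter). This position therefore accepted one aromatic ring in place of another with only a modest change, a 2.2-fold higher number from compound 1 to compound 2 (0.33 log units; beyond the scatter), whereas among these three compounds the one with a non-aromatic carbon ring has by far the highest number. Nothing available here accounts for this difference.

The swap changes several things at once, including aromaticity, ring size and the loss of ring nitrogen and chlorine, and these three compounds cannot separate them. A plain phenyl ring would show whether an aromatic ring of carbon alone restores the lower numbers, and a cyclohexyl group would test a larger non-aromatic ring.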